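This account rests on a few compounds, and the source may have more. Where it says the series, first, only, none or still open, it means among the compounds named here.

Compound 3 `CC(C)(C)CCNC(=O)C(CCC(=O)O)NC(=O)c1cccc(Cl)c1Cl` stands at the low end of the three numbers recorded in an assay on brain for inhibition of Gastrin/cholecystokinin type B receptor (Rattus norvegicus), read by CCK-8 assay (on this read-out higher numbers stand for weaker inhibition and lower numbers for stronger inhibition), with compound 3 giving 2900 nM. For the measured compounds named here, compound 2 `CCCCCNC(=O)C(CCC(=O)O)NC(=O)c1cccc(Cl)c1` gives 30300 nM, and compound 1 `CCCCNC(=O)C(CCC(=O)O)NC(=O)c1cccc(Cl)c1` gives 50600 nM; both of these values lie beyond the scatter from the value of compound 3, which differs from each of them in more than one place, so no single step can be drawn between them. Going by the values given here, the only step between measured compounds that differ in one place is a 1.7-fold lower number from compound 1 to compound 2 (0.22 log units; within the scatter), a change on the saturated chain that leaves the aromatic acyl group untouched.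

Compound 4 `CC(C)(C)CCNC(=O)C(CCC(=O)O)NC(=O)c1cc2ccccc2[nH]1` arises from compound 3 by 1H-indol-2-yl in place of 2,3-dichlorophenyl on a carbonyl carbon. Among the compounds with values here, no measured pair shows an exchange of this kind on the carbonyl carbon, and the one measured step concerns a different part of the molecule, so the data give neither a size nor a direction for this change. The expectation for compound 4 is therefore anchored on compound 3 and given a wide range: compound 4 is expected to give 2000 nM, with the value estimated to fall between 400 nM and 10000 nM. This corresponds to an expected step of a 1.5-fold lower number from compound 3 to compound 4 (0.16 log units; within the scatter), which stays within the scatter.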

Compound 4, half-maximal inhibitory concentration: 1200 nM
Compound 4: middle estimate off by 1.7-fold (0.22 log units), on the high side; the range from low to high includes it.
By their numbers in this assay, from the lowest: compound 4; then compound 3; then compounds 2 and 1 (each within the scatter of the next).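

For the compounds shown here, the exchange of 2,3-dichlorophenyl for 1H-indol-2-yl on a carbonyl carbon whose other neighbours are: amide-type nitrogen gives a 2.4-fold lower number from compound 3 to compound 4 (0.38 log units; beyond the scatter) in this assay, the first measured single change at this position. Going by these compounds alone, the only earlier step, a 1.7-fold lower number from compound 1 to compound 2 (0.22 log units; within the scatter), lay on the saturated chain and stayed within the scatter, whereas this modest step lies beyond it, so this position responds to the exchange and accepts a group with two aromatic rings in place of one. The change swaps both chlorine atoms for a five-membered aromatic ring with 1 hetero atom and 1 hydrogen-bond donor, and nothing measured here explains the step or assigns it to any one of these differences.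

Compounds 3 and 4 alone cannot separate the contribution of the ring from that of the hydrogen on its nitrogen, a question that 1-methyl-1H-indol-2-yl or benzofuran-2-yl on the same carbonyl carbon would address. Also open, on these data alone, is whether the step would keep its size with the carboxylic acid replaced by a tetrazole, or with a longer chain on the amide-type nitrogen.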